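Swapping a Methylphenyl for a Chlorophenyl in a Weak Series

The source may hold more compounds than are shown below. What is called first, only, known or untested is meant among the compounds shown, and "the series" means these compounds.

Two members of this series have been tested in a functional assay on NIH3T3 cells (Mus musculus); a lower number here means that less compound is needed, a higher number that more compound is needed for the effect. Compound 1 `COC(=O)[C@H](CCSC)NC(=O)c1ccc(NCc2cncn2Cc2ccc(C)cc2)cc1-c1ccccc1` gives only a limit there, > 10 uM, so no actual number is known for it. Compound 2 `CSCC[C@H](NC(=O)c1ccc(CNCc2[nH]cnc2C)cc1-c1ccccc1C)C(=O)O` likewise reaches only the limit of > 10 uM in this assay. Both known results therefore sit at the same edge of what the assay can report, as summarised by the limit of > 10 uM in this assay, at which 2 of the 2 values shown sit. Compound 1 thus stands at a boundary rather than at a measured point, and nothing in the shown data places it above or below any other compound.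

The unmeasured compound 3 `COC(=O)[C@H](CCSC)NC(=O)c1ccc(NCc2cncn2Cc2ccccc2Cl)cc1-c1ccccc1` is reached from compound 1 through a single change, (2-chlorophenyl in place of 4-methylphenyl on a saturated chain carbon bound to an aromatic nitrogen). Going by the values given here, no pair of measured compounds differs in only one place, so there is no measured step to lean on. With both known values resting on the limit, the expected step is a step that the limit leaves unreadable from compound 1 to compound 3, small and within the usual scatter, most likely leaving the new compound at the limit too. Compound 3 is therefore estimated at 15 uM, with a range from 5 uM to 50 uM.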

Compound 3, concentration for half-maximal effect: > 10 uM
Compound 3: a limit, no number; the forecaster's own chance of this, stated with the estimate: 75%; the middle value does not contradict the limit.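

In this assay compound 3 gives > 10 uM, a limit and not a number. With compound 1 also resting on a limit, no step can be read from compound 1 to compound 3: the limit of > 10 uM in this assay, at which 3 of the 3 values shown sit. The compounds shown leave open what concentration any of them needs for the effect, and whether 2-chlorophenyl or 4-methylphenyl gives the lower number.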